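Ortho substituent swap on a diaryl pyridinol series

The source may hold more compounds than are shown below. What is called first, only, known or untested is meant among the compounds shown, and "the series" means these compounds.

Measured so far:
compound 1 `Oc1ccc(-c2cc(-c3ccccc3F)cc(-c3cccc(O)c3)n2)cc1`, in a functional assay on T47D cells (Homo sapiens) for inhibition (on this read-out lower numbers stand for stronger inhibition and higher numbers for weaker inhibition), compound 1 gives 6370 nM
compound 2 `Oc1ccc(-c2cc(-c3ccccc3F)cc(-c3ccc(O)cc3)n2)cc1`, in this assay compound 2 gives 15100 nM

For the measured compounds named here, compound 1 holds the lower of the two numbers; the only step on record, a 2.4-fold higher number from compound 1 to compound 2 (0.37 log units; beyond the scatter), concerns the hydroxyphenyl and not the ortho position. Compound 3 `Oc1ccc(-c2cc(-c3ccccc3C(F)(F)F)cc(-c3cccc(O)c3)n2)cc1` differs from compound 1 by trifluoromethyl in place of fluoro on an aromatic carbon. Going by the values given here, no measured step bears on this change, so no direction can be read from the data. Compound 3 is therefore expected near compound 1, with a 1.1-fold lower number from compound 1 to compound 3 (0.03 log units; within the scatter) as the working guess. The estimate for compound 3 is 6000 nM, with a range from 2000 nM to 20000 nM.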

Compound 3, half-maximal inhibitory concentration: 3210 nM
Beside the measured number, compound 3's estimate is 1.9-fold (0.27 log units) above it, and the stated range covers the measured number.
By their numbers in this assay, from the lowest: compounds 3 and 1 (each within the scatter of the next); then compound 2.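

In this assay the swap of fluoro for trifluoromethyl gives a 2.0-fold lower number from compound 1 to compound 3 (0.30 log units; within the scatter), so compound 1 and compound 3 cannot be told apart on this read-out. The position, ortho to a large group, therefore carries either group with the number staying in the same range. Nothing on hand bears on what lies behind this result.

Still open, going by these compounds, is how an amine, a carboxylic acid or a methoxy group would read at this position. Also open, on these data alone, is whether trifluoromethyl reads the same alongside the 4-hydroxyphenyl of compound 2.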